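The source may hold more compounds than are shown below. What is called first, only, known or untested is meant among the compounds shown, and "the series" means these compounds.

In a functional assay (muscle tissue) with Cavia porcellus as the target (a higher number here means that more compound is needed for the effect, a lower number that less compound is needed), compound 1 `COC(=O)C1=C(C)NC(C)=C(C(=O)OC)C1c1ccccc1` gives 28.2 nM. Compound 2 `COC(=O)C1=C(C)N=C(C)/C(=C(\O)OC)C1c1ccc(F)cc1` gives 129 nM in this assay, and compound 3 `COC(=O)C1=C(C)N=C(C)/C(=C(\O)OC)C1c1ccc(I)cc1` gives 22900 nM, the highest of the three numbers. Among the measured compounds shown here, the one step that separates it from a measured neighbour is a 180-fold higher number from compound 2 to compound 3 (2.25 log units; beyond the scatter), where the only change is iodo in place of fluoro on an aromatic carbon. The gap from compound 1 to compound 3 is larger still, but those two compounds differ in more than one place, so only their two values can be set side by side.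

Compound 4 `COC(=O)C1=C(C)N=C(C)/C(=C(\O)OC)C1c1cccc(C#N)c1` is not yet measured. It differs from compound 3 as follows: 3-cyanophenyl in place of 4-iodophenyl on a saturated ring carbon. For the measured compounds named here, no measured step bears directly on this change, because no pair in the data exchanges a 4-iodophenyl for a 3-cyanophenyl. What the data do show is that compound 3, the one carrying 4-iodophenyl, stands far above compound 2 by a 180-fold higher number from compound 2 to compound 3 (2.25 log units; beyond the scatter). Removing that group is therefore expected to bring the number down, though how far is uncertain. The estimate for compound 4 in this assay is 500 nM, between 80 nM and 3000 nM, which is expected to amount to a 46-fold lower number from compound 3 to compound 4 (1.66 log units; beyond the scatter).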

Compound 4, half-maximal effective concentration: 34.7 nM
Estimate against measurement, compound 4: 14-fold (1.16 log units) above; the whole stated range lies above it.
By their numbers in this assay, from the lowest: compounds 1 and 4 (each within the scatter of the next); then compound 2; then compound 3.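

Exchanging the 4-iodophenyl for 3-cyanophenyl on the saturated ring carbon gives a 660-fold lower number from compound 3 to compound 4 (2.82 log units; beyond the scatter) in this assay, so the high number of compound 3 belongs to its 4-iodophenyl group and not to the position, which also accepts a larger aryl group by heavy-atom count with a low number. Measured against the 4-fluorophenyl group, the same 3-cyanophenyl group gives a 3.7-fold lower number from compound 2 to compound 4 (0.57 log units; beyond the scatter) and this modest step, though beyond the scatter, shows that a substituted phenyl at this position can lie below the fluoro compound as well as far above it, which the halogen pair alone could not show. No measurement of any property of these groups accompanies these steps, so the data offer no explanation for their size.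

In each of these steps the substituent and its place on the phenyl ring change together, so the compounds shown do not separate the effect of the nitrile from that of the 3-position, as a 4-cyanophenyl or a 3-iodophenyl group would. They also leave open how the number would respond to an amine or a carboxylic acid on the same phenyl ring.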